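Hydrazone aryl to methyl within the shared core

A few compounds are considered here, and "the series" means these few. Any claim that something is new, unique, unknown or untested is made for them only; others in the source may bear on it.

Compound 3 `Cc1cc(NN=C2CCC(C)n3c2ncc(C(=O)O)c3=O)ccc1Br` stands in a functional assay on the whole organism with Rattus norvegicus as the target (a higher number here means that more compound is needed for the effect, a lower number that less compound is needed), at a limit, > 100 umol/kg, which is a limit of the assay and not a number. Compound 1 `CC1CCC(=NNc2ccc(Cl)c(Cl)c2)c2ncc(C(=O)O)c(=O)n21` likewise gives in this assay a limit, > 100 umol/kg. Compound 2 `CC1CCC(=NNc2c(Cl)cccc2Cl)c2ncc(C(=O)O)c(=O)n21` also gives a limit, > 100 umol/kg. All three sit at the limit of > 100 umol/kg in this assay, at which 3 of the 3 values shown sit, so the steps a step that the two limits leave unreadable from compound 1 to compound 2, a step that the two limits leave unreadable from compound 1 to compound 3 and a step that the two limits leave unreadable from compound 2 to compound 3 carry no readable size. Compound 4 `CNN=C1CCC(C)n2c1ncc(C(=O)O)c2=O` differs from compound 3 by methyl in place of 4-bromo-3-methylphenyl on an amine nitrogen. Among the compounds with values here, no measured step bears readably on this exchange; aryl variation on the amine nitrogen left every value at the limit. Compound 4 is therefore expected to remain near the limit, with the step that the limit leaves unreadable from compound 3 to compound 4 estimated as small. The expected value for compound 4 is 150 umol/kg, within 40 umol/kg to 600 umol/kg, most probably reported again only as a limit.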

Compound 4, dose for 50% inhibition: > 100 umol/kg
Compound 4: only a limit was reported; the forecaster's own chance of this, stated with the estimate: 75%; the middle value does not contradict the limit.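

Within the data shown here, compound 4, like compound 1, compound 2 and compound 3, gives only a limit, so no step among them can be read: the limit of > 100 umol/kg in this assay, at which 4 of the 4 values shown sit. The compounds shown leave open whether any group on the amine nitrogen gives a measurable value in this assay.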